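The compounds below may be only part of what the source reports. "The series", "measured", "known", "first", "only" and "open" are said of these compounds alone.

Measured compounds:
compound 1 `CO/N=C1\C[C@@H](c2ccc(Cl)cc2)N[C@@H](c2ccc(Cl)cc2)[C@@H]1C` 49000 nM
compound 2 `CO/N=C1/[C@@H](C)[C@H](c2cccc(F)c2)N[C@H](c2cccc(F)c2)[C@H]1C` 37900 nM

In a functional assay on HeLa cells (Homo sapiens) for inhibition, read by MTT assay, with a stated time of 24 h (on this read-out higher numbers stand for weaker inhibition and lower numbers for stronger inhibition), compound 1 gives 49000 nM, and compound 2 gives 37900 nM; the two numbers lie within the usual scatter of each other, so neither compound is set apart. Compound 3 `CO/N=C1\C[C@@H](c2ccc(Cl)cc2)N(C)[C@@H](c2ccc(Cl)cc2)[C@@H]1C` is not yet measured. It differs from compound 1 by methyl in place of hydrogen on an amine nitrogen in a ring. No step of this kind is shown among the measured compounds, so no size or direction can be read from them; the step is expected to stay within the scatter. Compound 3 is estimated at 45000 nM, between 15000 nM and 130000 nM, which means a step of a 1.1-fold lower number from compound 1 to compound 3 (0.04 log units; within the scatter).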

Compound 3, half-maximal inhibitory concentration: 36300 nM
Beside the measured number, compound 3's estimate is 1.2-fold (0.09 log units) above it; the range from low to high includes it.
By their numbers in this assay, from the lowest: compounds 3, 2 and 1 (each within the scatter of the next).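

In this assay, methyl in place of hydrogen on the amine nitrogen in the ring gives a 1.3-fold lower number from compound 1 to compound 3 (0.13 log units; within the scatter) and this is the only reading of this position among the compounds shown. The ring nitrogen thus carries this one added carbon with no difference that can be told from the scatter. Nothing measured here bears on why this is so. The compounds shown leave open whether a benzyl or an acetyl group on this nitrogen would give a difference beyond the scatter. They also leave open whether methyl on the nitrogen of the core of compound 2 would read the same way.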